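The compounds below may be only part of what the source reports. "The series", "measured", "known", "first", "only" and "open" are said of these compounds alone.

Compounds measured in an assay on CHO-TREX cells for antagonist activity at transient receptor potential cation channel subfamily A member 1 (Homo sapiens), read by FLIPR and calcium flux, with a stated time of 10 min; a lower number here means a stronger inhibitor, a higher number a weaker inhibitor:
compound 1 `Clc1ccccc1-c1ccc2[nH]ncc2c1` gives 1230 nM
compound 3 `CC(C)(C)c1ccccc1-c1ccc2[nH]ncc2c1` gives 3400 nM
compound 2 `c1ccc(-c2ccc3[nH]ncc3c2)cc1` gives only a limit of this assay, > 30000 nM

Compound 3 holds the highest of the two numbers; the nearest is compound 1, and the step of a 2.8-fold higher number from compound 1 to compound 3 (0.44 log units; beyond the scatter) is modest. Compound 2 sits at the limit of > 30000 nM in this assay, at which 1 of the 3 values shown sits, and is not ranked.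

Compound 4 `FC(F)(F)c1ccccc1-c1ccc2[nH]ncc2c1` differs from compound 3 by trifluoromethyl in place of tert-butyl on an aromatic carbon. For the measured compounds named here, two measured steps bear on this change: a 2.8-fold higher number from compound 1 to compound 3 (0.44 log units; beyond the scatter), where tert-butyl gave a modestly higher number than chloro, and an at least 24-fold higher number from compound 1 to compound 2 (1.38 log units; beyond the scatter), where loss of the substituent gave a large rise. Trifluoromethyl keeps a substituent at that place, so a modest fall from compound 3 is expected in this assay, a 2.3-fold lower number from compound 3 to compound 4 (0.36 log units; beyond the scatter). Compound 4 is estimated at 1500 nM, with a range of 500 nM to 6000 nM.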

Compound 4, half-maximal inhibitory concentration: 164 nM
Estimate against measurement, compound 4: 9.1-fold (0.96 log units) above; the whole stated range lies above it.
By their numbers in this assay, from the lowest: compound 4; then compound 1; then compound 3. At a limit, above all of these: compound 2.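

At this place on the aromatic ring, trifluoromethyl in place of tert-butyl gives a 21-fold lower number from compound 3 to compound 4 (1.32 log units; beyond the scatter) even though both groups count the same heavy atoms, so that count alone does not set the number. Trifluoromethyl in place of chloro gives a 7.5-fold lower number from compound 1 to compound 4 (0.88 log units; beyond the scatter) and leaves compound 4 as the strongest inhibitor of the compounds shown. Trifluoromethyl in place of hydrogen gives an at least 180-fold lower number from compound 2 to compound 4 (2.26 log units; beyond the scatter) but this is only a bound, and compound 2 gives a limit: the limit of > 30000 nM in this assay, at which 1 of the 4 values shown sits.

Still open, going by these compounds, is how a nitrile, a methoxy group or an amine at this place compares with trifluoromethyl. Also open, on these data alone, is whether trifluoromethyl on another carbon of the same ring keeps this gain.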